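The source may hold more compounds than are shown below. What is called first, only, known or untested is meant among the compounds shown, and "the series" means these compounds.

Working notes on the series. Three compounds with a shared core have been run in a functional assay on C6 cells (Rattus norvegicus) for cytotoxicity, read by MTT assay, with a stated time of 24 h; a higher number here means a weaker inhibitor, a lower number a stronger inhibitor. Compound 1 `O=C(CSc1nnc(COc2ccc3c(c2)CCCC3)o1)Nc1nc2ccccc2s1` gives 153000 nM in this assay. Compound 2 `O=C(CSc1nnc(COc2ccc3c(c2)CCCC3)o1)Nc1nc2ccc([N+](=O)[O-])cc2s1` carries nitro in place of hydrogen on an aromatic carbon, and in this assay compound 2 gives 98300 nM; the step is a 1.6-fold lower number from compound 1 to compound 2 (0.19 log units; within the scatter). Compound 3 `O=C(CSc1nnc(COc2ccc3c(c2)CCCC3)o1)Nc1nccs1` differs from compound 1 by 1,3-thiazol-2-yl in place of 1,3-benzothiazol-2-yl on an amide-type nitrogen; in this assay compound 3 gives 213000 nM, with the step of a 1.4-fold higher number from compound 1 to compound 3 (0.14 log units; within the scatter). Among the compounds with values here, the values of compound 3 and compound 2 stand apart by more than the scatter, but no single step between them is counted.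

Compound 4 `O=C(CSc1nnc(COc2ccc3c(c2)CCCC3)o1)Nc1ncc([N+](=O)[O-])s1` has not yet been measured in this assay. It differs from compound 3 by nitro in place of hydrogen on an aromatic carbon. This is the same kind of change as from compound 1 to compound 2, and it occurs twice among the compounds shown. The place is not the same: in compound 2 the nitro sits on a six-membered aromatic ring of carbon only, part of a fused or bridged system of two rings, meta to a fused ring and para to a fused ring; in compound 4 it sits on a five-membered aromatic ring with 1 nitrogen and 1 sulfur, next to the ring sulfur, two ring bonds from the ring nitrogen. The two cores differ as already described for compound 3 against compound 1.

The step of a 1.5-fold lower number from compound 3 to compound 4 (0.18 log units; within the scatter) is expected to be small because the earlier step of a 1.6-fold lower number from compound 1 to compound 2 (0.19 log units; within the scatter) lay within the scatter. Compound 4 is therefore estimated at about 140000 nM in this assay, expected to fall between 60000 nM and 320000 nM.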

Compound 4, half-maximal inhibitory concentration: 66700 nM
The estimate for compound 4 lay 2.1-fold (0.32 log units) above the measured number, and the stated range covers the measured number.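

In this assay, nitro in place of hydrogen on the aromatic carbon next to the ring sulfur gives a 3.2-fold lower number from compound 3 to compound 4 (0.50 log units; beyond the scatter), beyond the scatter, while the same kind of change on the other core gave a 1.6-fold lower number from compound 1 to compound 2 (0.19 log units; within the scatter), within it. Both steps run in the same direction, and their sizes cannot be told apart: the same change on two cores in this assay, a 1.6-fold lower number (0.19 log units; within the scatter) from compound 1 to compound 2 and a 3.2-fold lower number (0.50 log units; beyond the scatter) from compound 3 to compound 4, 2.1-fold (0.31 log units) apart, within the scatter of two such steps This fits the change carrying over between these two cores and, with 5-nitro-1,3-thiazol-2-yl in place of 1,3-benzothiazol-2-yl giving a 2.3-fold lower number from compound 1 to compound 4 (0.36 log units; beyond the scatter), places compound 4 beyond the scatter from compound 1, but two pairs, with the nitro at a different place in each, do not show that the step has a fixed size, nor that it would hold on any further core.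

Going by these compounds, it remains open whether another group on that same aromatic carbon, such as an amine, a carboxylic acid or a nitrile, would give a step in the same direction, and whether nitro on a different carbon of either ring would match these steps. Also open, on these data alone, is how the numbers in this assay respond to a longer chain in place of the link between the shared core and the amide.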